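Methoxycarbonyl to carboxy on a shared core

This account rests on a few compounds, and the source may have more. Where it says the series, first, only, none or still open, it means among the compounds named here.

Results so far in a functional assay on K562 cells (Homo sapiens) for cytotoxicity, read by trypan blue exclusion, with a stated time of 96 h; on this read-out higher numbers stand for weaker inhibition and lower numbers for stronger inhibition:
- compound 1 `COc1ccc(/C=C/S(=O)(=O)Cc2ccc(OC)c(N)c2)c(OC)c1` gives 500 nM
- compound 2 `COc1cc(OC)c(/C=C/SCc2ccc(OC)c([N+](=O)[O-])c2)c(OC)c1` gives 5000 nM
- compound 3 `COC(=O)C(F)(F)Nc1cc(CS(=O)(=O)/C=C/c2c(OC)cc(OC)cc2OC)ccc1OC` gives 250 nM

In this assay compound 3 gives 250 nM and lies within the scatter of compound 1 at 500 nM on these numbers. Compound 2 at 5000 nM stands beyond the scatter from compound 3 and shows the weaker inhibition.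

The next compound is compound 4 `COc1cc(OC)c(/C=C/S(=O)(=O)Cc2ccc(OC)c(NC(F)(F)C(=O)O)c2)c(OC)c1` and it departs from compound 3 in one place only: hydrogen in place of methyl on an oxygen next to a carbonyl group. This is hydrogen in place of methyl on an oxygen next to a carbonyl group, so methoxycarbonyl becomes carboxy and difluoro(methoxycarbonyl)methyl becomes carboxy(difluoro)methyl.

Among the compounds with values here, no measured pair isolates this change, so the data offer no direct size for it. Within the data shown here, the only guide is that compound 3 at 250 nM and compound 1 at 500 nM differ in more than one place and still stay within the scatter. A small move towards a higher number is therefore expected, and none beyond the scatter. The estimated step is a 1.2-fold higher number from compound 3 to compound 4 (0.08 log units; within the scatter) in this read-out. Compound 4 is estimated at 300 nM with 80 nM and 1200 nM as the ends of its expected range.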

Compound 4, half-maximal inhibitory concentration: 150 nM
Compound 4: the middle estimate sits 2.0-fold (0.30 log units) above what was measured; low and high end bracket the measured number.
By their numbers in this assay, from the lowest: compounds 4, 3 and 1 (each within the scatter of the next, the first and the last beyond it); then compound 2.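

Hydrogen in place of methyl on an oxygen next to a carbonyl group gives the first step in this assay between compounds that differ in one place, and it reads a 1.7-fold lower number from compound 3 to compound 4 (0.22 log units; within the scatter) for methoxycarbonyl becoming carboxy. At this position, then, difluoro(methoxycarbonyl)methyl and carboxy(difluoro)methyl cannot be told apart on these numbers, and the methyl on that oxygen can be exchanged for hydrogen without the value leaving the usual scatter of the read-out. No separate measurement on these compounds bears on why the two numbers stay so close.

The compounds shown leave open what an ethyl ester, a primary amide or a longer chain carrying the carboxylic acid would give at this place on the shared core. They also leave open what hydrogen in place of fluorine on the same chain would do, and whether the methoxycarbonyl to carboxy step would read the same on a core with a different pattern of methoxy groups.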